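Swapping the Aryl Group on a Weakly Active Scaffold

The source may report more compounds than this note shows. Statements on the series, on what has been measured and on what is new or still open speak of the compounds shown alone.

Compound 1, `Cc1ccc(N2CCN(Cn3nc(-c4ccc5c(c4)OCCO5)oc3=S)CC2)c(C)c1`, in a functional assay on BGC-823 cells (Homo sapiens) for antiproliferative activity, read by MTT assay, with a stated time of 48 h (on this read-out lower numbers stand for stronger inhibition and higher numbers for weaker inhibition), gives 28300 nM.
Compound 2, `O=[N+]([O-])c1ccc(N2CCN(Cn3nc(-c4ccc5c(c4)OCCO5)oc3=S)CC2)cc1`, in this assay reaches only the assay limit > 50000 nM.
Compound 3, `S=c1oc(-c2ccc3c(c2)OCCO3)nn1CN1CCN(c2ccccc2Cl)CC1`, in this assay reaches only the assay limit > 50000 nM.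

Compound 1 is the only one of the three to give a number; the other two sit at a limit (the limit of > 50000 nM in this assay, at which 2 of the 3 values shown sit). Compound 4, `S=c1oc(-c2ccc3c(c2)OCCO3)nn1CN1CCN(c2cccc(Cl)c2Cl)CC1`, differs from compound 1 by 2,3-dichlorophenyl in place of 2,4-dimethylphenyl on an amine nitrogen in a ring. Within the data shown here, the steps that bear on this change are an at least 1.7-fold higher number from compound 1 to compound 2 (0.24 log units; that floor lies within the scatter) and an at least 1.7-fold higher number from compound 1 to compound 3 (0.24 log units; that floor lies within the scatter), each replacing the same aryl group and each ending at the limit. Compound 4 is therefore expected to move in the same direction, towards weaker inhibition, with a 1.8-fold higher number from compound 1 to compound 4 (0.25 log units; within the scatter) as the estimated step. For compound 4 the expected value is 50000 nM, between 18000 nM and 140000 nM, and a limit rather than a number is likely.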

Compound 4, half-maximal inhibitory concentration: 22600 nM
Compound 4: middle estimate off by 2.2-fold (0.34 log units), on the high side; measured number inside the range.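

In this assay, the aryl group on the amine nitrogen can change without the result ending at the limit: 2,3-dichlorophenyl in place of 2,4-dimethylphenyl gives a 1.3-fold lower number from compound 1 to compound 4 (0.10 log units; within the scatter). The second chloro matters, with chloro in place of hydrogen on an aromatic carbon giving an at least 2.2-fold lower number from compound 3 to compound 4 (0.34 log units; beyond the scatter), and the swap from 4-nitrophenyl gives an at least 2.2-fold lower number from compound 2 to compound 4 (0.34 log units; beyond the scatter). Compound 2 and compound 3 each stand at a limit, so these last two steps are floors: the limit of > 50000 nM in this assay, at which 2 of the 4 values shown sit.

On these data alone, only compound 1 and compound 4 give numbers, so the true size of those two steps stays open. Also open, as far as these compounds go, is whether an amine or a carboxylic acid on the aryl ring would give a lower number.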